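Benzoyl Gives Way to 4-Chlorophenyl

The compounds below may be only part of what the source reports. "The series", "measured", "known", "first", "only" and "open" are said of these compounds alone.

Of the compounds shown here, three sharing one core have been tested in an ADME assay on HEK293 cells (Homo sapiens) for cytotoxicity, with a stated time of 72 h (a lower number here means that less compound is needed, a higher number that more compound is needed for the effect), and none of them has yet given a number. Compound 1 (`C=C[C@@](C)(/C=C/c1ccc(OS(=O)(=O)C(F)(F)F)cc1)CCC=C(C)C`) gives > 36600 nM, which is a limit of the assay. Compound 2 (`C=C[C@@](C)(/C=C/c1ccc(O)cc1)CC/C=C(\C)C=O`) also gives only a limit, > 36600 nM. Together these two make up (the limit of > 36600 nM in this assay, at which 2 of the 3 values shown sit).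

Compound 3 (`C=C[C@@](C)(/C=C/c1ccc(O)c(/C=C/C(=O)c2ccccc2)c1)CCC=C(C)C`) likewise stands at a limit, > 7410 nM. It is the only compound at this limit, as shown by the limit of > 7410 nM in this assay, at which 1 of the 3 values shown sits. Its true position in this assay is therefore not known, and the three results cannot be ranked.

Compound 4 (`C=C[C@@](C)(/C=C/c1ccc(O)c(/C=C/c2ccc(Cl)cc2)c1)CCC=C(C)C`) has 4-chlorophenyl in place of benzoyl on a double-bonded chain carbon bound to a double-bonded chain carbon. For the measured compounds named here, the data contain no step between measured compounds, so nothing shows how large an effect such a change has in this assay. No shift beyond the usual scatter is expected, in either direction. On that reading, the expected move is a step that the limit leaves unreadable from compound 3 to compound 4. A report of only a limit is also considered the likeliest outcome. For compound 4 the estimated value is 9000 nM, with an expected range from 3000 nM to 37000 nM.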

Compound 4, half-maximal effective concentration: > 36600 nM
Compound 4 ended at the assay's limit; the forecaster's own chance of this, stated with the estimate: 70%; at least 4.0-fold (0.60 log units) between middle value and limit.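

In this assay compound 4 gives > 36600 nM, a limit of the assay. Compound 3 also gives only a limit, > 7410 nM. The step from compound 3 to compound 4 therefore cannot be read. The compounds shown leave open where any of the four truly stands in this assay, and how much 4-chlorophenyl in place of benzoyl changes the result.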